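A few compounds are considered here, and "the series" means these few. Any claim that something is new, unique, unknown or untested is made for them only; others in the source may bear on it.

Compound 1 `CC1CCC(C)N1CCCNC(=O)C(c1ccccc1)c1ccccc1` gives 4600 nM in an assay on CHO cells for inhibition of sodium channel protein type 2 subunit alpha (Rattus norvegicus); a higher number here means a weaker inhibitor, a lower number a stronger inhibitor.
Compound 2 `CC1CN(CCCNC(=O)C(c2ccccc2)c2ccccc2)CC(C)O1` gives 2700 nM in this assay.

For the measured compounds named here, compound 2 stands close to compound 1: the only measured step, a 1.7-fold lower number from compound 1 to compound 2 (0.23 log units; within the scatter), falls within the scatter, so the two compounds cannot be told apart on these numbers. Compound 3 `O=C(NCCCCN1CCCCC1)C(c1ccccc1)c1ccccc1` is built from the same core, and its change from compound 2 is (piperidin-1-yl)methyl in place of 2,6-dimethylmorpholin-4-yl on a saturated chain carbon, three bonds along the chain from an amide-type nitrogen. Going by the values given here, the one step that bears on this is the ring swap from compound 1 to compound 2, which also exchanged one saturated ring for another at the same place and left the number essentially unchanged. Among the compounds with values here, with only that comparison at hand, the expectation for compound 3 in this assay is a step of about a 1.1-fold higher number from compound 2 to compound 3 (0.05 log units; within the scatter), in no particular direction beyond the scatter. Compound 3 is therefore estimated at 3000 nM, with a likely range from 1000 nM to 9000 nM.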

Compound 3, half-maximal inhibitory concentration: 10000 nM
For compound 3 the middle estimate is 3.3-fold (0.52 log units) below the measured one; measured number outside the range, above it.
By their numbers in this assay, from the lowest: compounds 2 and 1 (each within the scatter of the next); then compound 3.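

In this assay, the position is not indifferent to every change: the swap to (piperidin-1-yl)methyl gives a 3.7-fold higher number from compound 2 to compound 3 (0.57 log units; beyond the scatter), and against the other ring it gives a 2.2-fold higher number from compound 1 to compound 3 (0.34 log units; beyond the scatter), so compound 3 is the weakest inhibitor of the three. Unlike the ring swap between the two earlier compounds, this change alters two things at once, replacing the ring and placing it on a longer chain, as the reading 2-(piperidin-1-yl)ethyl shows. Nothing measured here explains the shift.

The compounds shown cannot separate the effect of the ring from that of the longer chain. A piperidin-1-yl group at the place held by the ring of compound 2, or 2,6-dimethylmorpholin-4-yl on the longer chain of compound 3, would pull the two apart.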